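Replacing the thioether in a guanidine acylbenzamide series

The source may hold more compounds than are shown below. What is called first, only, known or untested is meant among the compounds shown, and "the series" means these compounds.

Of the compounds shown here, three share one core and have been tested in a functional assay for inhibition of sodium/hydrogen exchanger (Oryctolagus cuniculus); on this read-out lower numbers stand for stronger inhibition and higher numbers for weaker inhibition. Compound 1 `CCSc1cc(C)c(C(=O)N=C(N)N)cc1S(C)(=O)=O` gives 5.9 nM. Compound 2 `CCCSc1cc(C)c(C(=O)N=C(N)N)cc1S(C)(=O)=O` gives 6.8 nM in this assay. Compound 3 `Cc1cc(SC(C)C)c(S(C)(=O)=O)cc1C(=O)N=C(N)N` gives 12 nM in this assay; this is the highest of the three numbers, with compound 2 nearest and compound 1 furthest. The step of a 2.0-fold higher number from compound 1 to compound 3 (0.31 log units; beyond the scatter) is modest, while the steps of a 1.2-fold higher number from compound 1 to compound 2 (0.06 log units; within the scatter) and a 1.8-fold higher number from compound 2 to compound 3 (0.25 log units; within the scatter) lie within the scatter.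

Compound 4 `COc1cc(C)c(C(=O)N=C(N)N)cc1S(C)(=O)=O` differs from compound 3 in one place: methoxy in place of isopropylsulfanyl on an aromatic carbon. For the measured compounds named here, none of the measured steps swaps the sulfur of the thioether for an oxygen; they only lengthen or branch the chain on the sulfur, and each of them moved the number by a small amount. The closest point of reference is that the smaller chains of compound 1 and compound 2 gave the lower numbers. Because a 1.2-fold higher number from compound 1 to compound 2 (0.06 log units; within the scatter) and a 2.0-fold higher number from compound 1 to compound 3 (0.31 log units; beyond the scatter) never exceeded a modest size, and a 1.8-fold higher number from compound 2 to compound 3 (0.25 log units; within the scatter) stayed within the scatter, only a small step is expected here too, in either direction. Compound 4 is therefore estimated at 10 nM in this assay, within 3 nM to 40 nM, an expected step of a 1.2-fold lower number from compound 3 to compound 4 (0.08 log units; within the scatter).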

Compound 4, half-maximal inhibitory concentration: 16 nM
For compound 4 the middle estimate is 1.6-fold (0.20 log units) below the measured one; measured number inside the range.
By their numbers in this assay, from the lowest: compounds 1, 2, 3 and 4 (each within the scatter of the next, the first and the last beyond it).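

In this assay, the aromatic carbon ortho to a methylsulfonyl group still gives a number in the same range when an oxygen-linked group replaces a sulfur-linked one: methoxy in place of isopropylsulfanyl gives a 1.3-fold higher number from compound 3 to compound 4 (0.12 log units; within the scatter), so against the branched thioether the sulfur makes no difference that can be read. Against the two unbranched thioethers the same exchange can be read, though it remains small: methoxy in place of propylsulfanyl gives a 2.4-fold higher number from compound 2 to compound 4 (0.37 log units; beyond the scatter), and methoxy in place of ethylsulfanyl gives a 2.7-fold higher number from compound 1 to compound 4 (0.43 log units; beyond the scatter), both modest steps beyond the scatter. Nothing measured here speaks to why the numbers fall as they do.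

Methoxy differs from each thioether in both the linking atom and the chain, so the compounds shown do not separate the oxygen from the shorter chain; ethoxy, set against ethylsulfanyl, would part the two. Also open, as far as these compounds go, is how this carbon responds to a different linking group, such as an amine, or to a longer chain on sulfur, such as butylsulfanyl.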